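The compounds below may be only part of what the source reports. "The series", "measured", "known", "first", "only" and "open" are said of these compounds alone.

Working notes on the amide series. Compound 1 `C[C@@H]1C[C@@H]1C(=O)N1CC2CNCC2C1` carries a dimethylcyclopropyl carbonyl group on the shared core; in an assay on CHO cells for displacement of a labelled ligand from Neuronal acetylcholine receptor; alpha3/beta4 (Homo sapiens), read by scintillation counting, with a stated time of 2 h (on this read-out lower numbers stand for stronger inhibition and higher numbers for weaker inhibition), compound 1 gives 280 nM. Compound 2 `CC(=O)N1CC2CNCC2C1` is the acetyl analogue, and in this assay compound 2 gives 14000 nM, the highest number of the two measured. Among the compounds with values here, the single measured step, a 50-fold higher number from compound 1 to compound 2 (1.70 log units; beyond the scatter), is a large loss that accompanies cutting the carbonyl substituent down to a single carbon.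

Compound 3 `CCC(=O)N1CC2CNCC2C1` follows from compound 2 by methyl in place of hydrogen on a saturated chain carbon bound to a carbonyl carbon, giving a propanoyl amide in place of acetyl. Within the data shown here, only the step from compound 1 to compound 2 bears on this change, and it concerns a larger group than a single methyl, so the expected effect is a partial recovery rather than a full return. For compound 3 the expected step is a 2.8-fold lower number from compound 2 to compound 3 (0.45 log units; beyond the scatter), a moderate decrease in this assay. The estimate for compound 3 is 5000 nM, with a range from 1500 nM to 15000 nM.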

Compound 3, inhibition constant: 2100 nM
Estimate against measurement, compound 3: 2.4-fold (0.38 log units) above; the range from low to high includes it.
By their numbers in this assay, from the lowest: compound 1; then compound 3; then compound 2.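

In this assay, one added methyl on the saturated chain carbon bound to a carbonyl carbon is enough to shift the number, with a 6.7-fold lower number from compound 2 to compound 3 (0.82 log units; beyond the scatter), so this position responds to a change much smaller than the one first seen. The propanoyl amide does not close the whole gap, with a 7.5-fold higher number from compound 1 to compound 3 (0.88 log units; beyond the scatter), and across these three compounds the number falls as the group on the carbonyl grows, with none going against that order. No supporting data bear on why either step has its size.

Going by these compounds, whether the ring of compound 1 matters in itself, or only the size of the group, stays open, and an open butanoyl chain or an unsubstituted cyclopropyl group would bear on that. On these data alone, how an amine or a hydroxyl on the same chain carbon would compare with methyl also remains unknown.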